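Replacing Isopropyl with (Pyridin-2-yl)methoxy on the Carbonyl Carbon

A few compounds are considered here, and "the series" means these few. Any claim that something is new, unique, unknown or untested is made for them only; others in the source may bear on it.

Of the compounds shown here, two with a shared core have been measured. Compound 1 `CNC(=O)c1cc(C)n(Cc2cc(Cl)ccc2OCc2ccccc2)n1` in an assay on CHO-K1 cells for displacement of a labelled ligand from prostaglandin E2 receptor EP1 subtype (Homo sapiens) (a higher number here means a weaker inhibitor, a lower number a stronger inhibitor), gives 100 nM. Among the compounds with values here, compound 2 `Cc1cc(NC(=O)C(C)C)nn1Cc1cc(Cl)ccc1OCc1ccccc1` in this assay gives 25.1 nM, the lowest of the two numbers; its nearest neighbour is compound 1, reached through the single measured step, a 4.0-fold lower number from compound 1 to compound 2 (0.60 log units; beyond the scatter), which was of modest size.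

Compound 3 `Cc1cc(NC(=O)OCc2ccccn2)nn1Cc1cc(Cl)ccc1OCc1ccccc1` differs from compound 2 in one place: (pyridin-2-yl)methoxy in place of isopropyl on a carbonyl carbon. Within the data shown here, the only measured step, from compound 1 to compound 2, concerns a change on an aromatic carbon rather than on the carbonyl carbon that is altered here, so no measured step bears directly on this change. The data give no guide to the direction of the new step, and the account therefore expects no step beyond the usual scatter in this assay, with the uncertainty wide on both sides.

On that basis compound 3 is estimated in this assay at 25 nM, with a range from 8 nM to 80 nM, which means an expected step of a 1.0-fold lower number from compound 2 to compound 3 (0.00 log units; within the scatter).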

Compound 3, half-maximal inhibitory concentration: 79.4 nM
Compound 3: the middle estimate sits 3.2-fold (0.50 log units) below what was measured; low and high end bracket the measured number.
By their numbers in this assay, from the lowest: compound 2; then compounds 3 and 1 (each within the scatter of the next).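

Within the data shown here, at the carbonyl carbon, the one change measured in this assay is a 3.2-fold higher number from compound 2 to compound 3 (0.50 log units; beyond the scatter), so (pyridin-2-yl)methoxy, with its six-membered aromatic ring and 2 hydrogen-bond acceptors, does not hold the number that isopropyl gave in compound 2. Read one bond further out, on the aromatic carbon, the comparison with methylcarbamoyl gives a 1.3-fold lower number from compound 1 to compound 3 (0.10 log units; within the scatter); the advantage of (isopropylcarbonyl)amino over methylcarbamoyl therefore does not carry over to (((pyridin-2-yl)methoxy)carbonyl)amino, and the numbers of compound 1 and compound 3 stay within the scatter of each other. Nothing available accounts for the difference between the two groups on the carbonyl carbon.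

The compounds shown leave open whether the higher number goes with the oxygen that links the new group to the carbonyl carbon or with the pyridine ring itself. A benzyloxy group, with a plain phenyl ring in place of the pyridine, or a methoxy group with no ring at all, on the same carbonyl carbon, would begin to separate the two.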